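Methylation of a phenol in a cytotoxicity series

The compounds below may be only part of what the source reports. "The series", "measured", "known", "first", "only" and "open" are said of these compounds alone.

Measured compounds:
Compound 1 `O=C(/C=C/c1ccc(O)c(O)c1)OCc1c(-c2ccccc2)no[n+]1[O-]` gives 7680 nM in a functional assay on Calu-1 cells (Homo sapiens) for cytotoxicity, read by resazurin assay, with a stated time of 72 h; a higher number here means a weaker inhibitor, a lower number a stronger inhibitor.
Compound 2 `COc1cc(/C=C/C(=O)OCc2c(-c3ccccc3)no[n+]2[O-])ccc1O` gives 22900 nM in this assay.
For compound 3 `O=C(/C=C/c1ccc(OCCCCCCO[N+](=O)[O-])c(O)c1)OCCCCCCO[N+](=O)[O-]` only a limit is reported in this assay, namely > 50000 nM.

Compounds 1 and 2 share one core and differ in a single place: methyl in place of hydrogen on an oxygen on an aromatic ring. That change produced a 3.0-fold higher number from compound 1 to compound 2 (0.47 log units; beyond the scatter), so the methylated compound 2 is the weaker of the pair. Compound 3 carries a different core, and the difference between the two cores is not broken down here.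

Compound 4 `COc1cc(/C=C/C(=O)OCCCCCCO[N+](=O)[O-])ccc1OCCCCCCO[N+](=O)[O-]` has not yet been measured in this assay. Among the compounds with values here, it differs from compound 3 by methyl in place of hydrogen on an oxygen on an aromatic ring, which is the same change as the one from compound 1 to compound 2, made at the same kind of place. In the measured pair this change weakened the compound, and compound 3 already sits at the limit of > 50000 nM in this assay, at which 1 of the 3 values shown sits. For compound 4 the expected step is a step that the limit leaves unreadable from compound 3 to compound 4, resting on the measured step of a 3.0-fold higher number from compound 1 to compound 2 (0.47 log units; beyond the scatter). Because compound 3 gives > 50000 nM, the most likely outcome for compound 4 is again a limit rather than a number. Compound 4 is estimated at 120000 nM, with a plausible range from 50000 nM to 400000 nM.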

Compound 4, half-maximal inhibitory concentration: 27800 nM
Estimate against measurement, compound 4: 4.3-fold (0.64 log units) above; measured number below the stated range.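

In this assay, the change from hydroxy to methoxy did not carry over cleanly from one core to the other, since an at least 1.7-fold lower number from compound 3 to compound 4 (0.25 log units; that floor lies within the scatter) points the opposite way to a 3.0-fold higher number from compound 1 to compound 2 (0.47 log units; beyond the scatter), and the gap between the two steps is larger than repeat measurements would explain: the same change on two cores in this assay, a 3.0-fold higher number (0.47 log units; beyond the scatter) from compound 1 to compound 2 and an at least 1.7-fold lower number (0.25 log units; that floor lies within the scatter) from compound 3 to compound 4, at least 5.3-fold (0.72 log units) apart, beyond the scatter of two such steps
The value of compound 3 is a limit of the assay and not a number, > 50000 nM.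
The two pairs therefore show that the result of this methylation on one core cannot simply be assumed for the other, but they do not show how large the step on the second core really is, nor which part of the two cores sets the steps apart.

The compounds shown leave open whether this difference follows the core of compound 1 as a whole or the chains carried by compound 3 and compound 4. A shorter or longer chain in their place, or an amine or a carboxylic acid at the end of the chain, could help to tell whether the methylation then behaves as it did from compound 3 to compound 4 or as it did from compound 1 to compound 2.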